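Removing the Acetyl Group: Expected Cytotoxicity of Compound 4

The source may hold more compounds than are shown below. What is called first, only, known or untested is meant among the compounds shown, and "the series" means these compounds.

Of the compounds shown here, three sharing one core have been measured in a functional assay on A549 cells (Homo sapiens) for cytotoxicity, with a stated time of 48 h; on this read-out lower numbers stand for stronger inhibition and higher numbers for weaker inhibition. Compound 1 `CC(C)CCOc1ccc2oc(/C=C/[S+](C)[O-])cc(=O)c2c1` gives 1000 nM. Compound 2 `COc1ccc2oc(/C=C/[S+](C)[O-])cc(=O)c2c1` gives 1600 nM, and compound 3 `CC(=O)Oc1ccc2oc(/C=C/[S+](C)[O-])cc(=O)c2c1` gives 4100 nM. Compound 3 thus shows the highest number of the three: the step of a 2.6-fold higher number from compound 2 to compound 3 (0.41 log units; beyond the scatter) and the step of a 4.1-fold higher number from compound 1 to compound 3 (0.61 log units; beyond the scatter) both lie beyond the scatter, whereas the step of a 1.6-fold higher number from compound 1 to compound 2 (0.20 log units; within the scatter) does not.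

Compound 4 `C[S+]([O-])/C=C/c1cc(=O)c2cc(O)ccc2o1` has not yet been measured. It differs from compound 3 in one place: hydrogen in place of acetyl on an oxygen on an aromatic ring. The two measured steps that bear on this change are the two that lead to compound 3, in which an acetyl took the place of an alkyl group on the same oxygen and the number rose modestly each time. Among the measured compounds shown here, no measured compound carries a bare hydrogen on that oxygen, so the step to compound 4 is less certain than a step between two alkyl groups would be. Because the steps of a 2.6-fold higher number from compound 2 to compound 3 (0.41 log units; beyond the scatter) and a 4.1-fold higher number from compound 1 to compound 3 (0.61 log units; beyond the scatter) both rose when the acetyl arrived, removing it is expected to lower the number modestly, by about a 2.1-fold lower number from compound 3 to compound 4 (0.31 log units; beyond the scatter). Compound 4 is therefore estimated at 2000 nM in this assay, within a range of 800 nM to 5000 nM.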

Compound 4, half-maximal inhibitory concentration: 10500 nM
Beside the measured number, compound 4's estimate is 5.3-fold (0.72 log units) below it; measured number outside the range, above it.
By their numbers in this assay, from the lowest: compounds 1 and 2 (each within the scatter of the next); then compound 3; then compound 4.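

Among the compounds shown here, on the oxygen on the aromatic ring, the change from acetoxy to hydroxy gives a 2.6-fold higher number from compound 3 to compound 4 (0.41 log units; beyond the scatter) in this assay, so the acetyl group, which had given the highest number so far, still gives a lower number than a bare hydrogen. Against the alkyl groups the effect is wider, with a 6.6-fold higher number from compound 2 to compound 4 (0.82 log units; beyond the scatter) when hydrogen replaces methyl and an 11-fold higher number from compound 1 to compound 4 (1.02 log units; beyond the scatter) when it replaces isopentyl, so all three groups measured on this oxygen give lower numbers than hydrogen does. The earlier compounds compared only one group with another, whereas compound 4 shows that having any of these groups on the oxygen matters more than the choice among them, though no measurement shown explains why.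

The compounds shown carry only methyl, isopentyl and acetyl on this oxygen, and compound 1 and compound 2 lie within the usual scatter of each other, so it remains open whether a longer chain, a benzyl group or a chain ending in an amine would lower the number further. As far as these compounds go, it is also open whether the same order of groups would hold in cells other than those of this single assay.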